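Replacing trifluoromethyl by fluoro on the aryl substituent

The source may hold more compounds than are shown below. What is called first, only, known or untested is meant among the compounds shown, and "the series" means these compounds.

Within the data shown here, compound 2 `Cn1nc2c(=O)n(CC3(O)CCN(Cc4ccc(-c5ccco5)cc4Cl)CC3)cnc2c1-c1ccc(C(F)(F)F)cc1` is the weaker of the two compounds measured so far: in an assay on isolated protein for inhibition of ubiquitin carboxyl-terminal hydrolase 7 (Homo sapiens), with stated times of 30 min and 2 h (on this read-out higher numbers stand for weaker inhibition and lower numbers for stronger inhibition), compound 2 gives 530 nM, the highest of the two numbers. Among the measured compounds shown here, its nearest neighbour, compound 1 `Cn1nc2c(=O)n(CC3(O)CCN(Cc4ccc(-c5ccco5)cc4Cl)CC3)cnc2c1-c1ccc(CNC=O)cc1`, gives 20.9 nM in this assay, and the single measured step, a 25-fold higher number from compound 1 to compound 2 (1.40 log units; beyond the scatter), lies well beyond the scatter. Compound 3 `Cn1nc2c(=O)n(CC3(O)CCN(Cc4ccc(-c5ccco5)cc4Cl)CC3)cnc2c1-c1ccc(F)cc1` is not yet measured. Its change from compound 2 is fluoro in place of trifluoromethyl on an aromatic carbon of a six-membered aromatic ring of carbon only. For the measured compounds named here, no measured step exchanges trifluoromethyl for fluoro; the only step available shows that what sits at this position can move the number a great deal, but it says nothing about the direction for this particular exchange. The expectation for compound 3 is therefore a step of a 1.5-fold lower number from compound 2 to compound 3 (0.18 log units; within the scatter) in this assay, small and of uncertain direction. Compound 3 is estimated at 350 nM in this assay, within a range of 100 nM to 1500 nM.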

Compound 3, half-maximal inhibitory concentration: 64.5 nM
For compound 3 the middle estimate is 5.4-fold (0.73 log units) above the measured one; measured number below the stated range.
By their numbers in this assay, from the lowest: compound 1; then compound 3; then compound 2.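

In this assay, the exchange of trifluoromethyl for fluoro on the aromatic carbon is a step in its own right (an 8.2-fold lower number from compound 2 to compound 3 (0.91 log units; beyond the scatter)), so this position responds even to a change between two groups counted with no hydrogen-bond donors and no hydrogen-bond acceptors. The 4-fluorophenyl compound 3 also lies much closer to compound 1 than compound 2 does, although a gap beyond the scatter remains (a 3.1-fold higher number from compound 1 to compound 3 (0.49 log units; beyond the scatter)). The (formylamino)methyl group is therefore not needed for a number well under that of compound 2, yet compound 1 still gives the lowest number of the three. No independent data bear on why these steps have this size or direction.

A single pair of halogen-bearing substituents does not show whether the trend continues to plain hydrogen, chloro or methyl at this position, and so gives no general rule. On these data alone, it also remains open which part of the (formylamino)methyl group carries the gain over fluoro, a question that an aminomethyl group, an acetamide or a carboxylic acid at the same place could address.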